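Moving the Ring Nitrogen: Expected Cytotoxicity of Compound 4

This account rests on a few compounds, and the source may have more. Where it says the series, first, only, none or still open, it means among the compounds named here.

Compound 1 `NCCCCCCC(=O)Nc1nc2ccc(C(=O)c3ccccc3)cc2[nH]1` — in an ADME assay on CRL8155 cells (Homo sapiens) for cytotoxicity, read by resazurin assay, with a stated time of 72 h (on this read-out lower numbers stand for an effect already at smaller amounts and higher numbers for an effect only at larger amounts of compound), compound 1 gives > 30000 nM, a limit of the assay.
Compound 2 `O=C(CCCC1CCNCC1)Nc1nc2ccc(C(=O)c3ccccc3)cc2[nH]1` — in this assay compound 2 gives > 30000 nM, a limit of the assay.
Compound 3 `CN1CCC(Cn2c(N)nc3ccc(C(=O)c4ccccc4)cc32)CC1` — in this assay compound 3 gives > 30000 nM, a limit of the assay.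

None of the three measured compounds returns a number in this assay; each stops at a limit. Compound 3 stands exactly where the other two stand, at the limit of > 30000 nM in this assay, at which 3 of the 3 values shown sit. Among the measured compounds shown here, the only step measured between two compounds, a step that the two limits leave unreadable from compound 1 to compound 2, cannot be read, both of its ends sitting at that limit.

Compound 4 `Nc1nc2ccc(C(=O)c3ccccc3)cc2n1CCN1CCCCC1` differs from compound 3 by (piperidin-1-yl)methyl in place of 1-methylpiperidin-4-yl on a saturated chain carbon bound to an aromatic nitrogen. The two share every atom and differ only in how the atoms are joined. No measured step bears on this change in a readable way: the one step shown is unreadable, and the three limits say only that no compound has shown an effect up to the limit. The step that the limit leaves unreadable from compound 3 to compound 4 is therefore expected to be none that can be seen, with compound 4 most likely returning a limit as well. Compound 4 is expected at 40000 nM, with a range from 20000 nM to 100000 nM.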

Compound 4, half-maximal effective concentration: > 30000 nM
Compound 4: only a limit was reported; the forecaster's own chance of this, stated with the estimate: 85%; the middle value does not contradict the limit.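

Among the compounds shown here, compound 3 and compound 4 each give only a limit of the assay and not a number, so no step between them can be read: the limit of > 30000 nM in this assay, at which 4 of the 4 values shown sit. The compounds shown leave open at what concentration, if any, each would affect these cells in this assay, and whether (piperidin-1-yl)methyl in place of 1-methylpiperidin-4-yl changes that concentration.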